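Removing a Methoxy Group: Two Places, One Kind of Change

The source may hold more compounds than are shown below. What is called first, only, known or untested is meant among the compounds shown, and "the series" means these compounds.

Of the compounds shown here, three have been measured in a functional assay on COLO 205 cells (Homo sapiens) for inhibition, read by sulforhodamine B assay, with a stated time of 48 h; a higher number here means a weaker inhibitor of growth, a lower number a stronger inhibitor of growth. Compound 2 `COc1ccc(-c2[nH]c3ccc(OC)cc3c2C=C(C#N)C#N)cc1` gives 291 nM there. Compound 1 `COc1ccc2[nH]c(-c3ccccc3)c(C=C(C#N)C#N)c2c1` gives 2100 nM in this assay. Between them stands one change, (hydrogen in place of methoxy on an aromatic carbon), and that change made a step of a 7.2-fold higher number from compound 2 to compound 1 (0.86 log units; beyond the scatter). Compound 3 `COc1ccc2[nH]c(-c3ccccc3)c(/C=C(\C#N)S(=O)(=O)c3ccccc3)c2c1` gives 7400 nM in this assay, the highest of the three numbers. The difference between the core of compound 3 and the core of compound 2 is not broken down here; the two values alone show compound 3 well above compound 2.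

Compound 4 `N#C/C(=C\c1c(-c2ccccc2)[nH]c2ccccc12)S(=O)(=O)c1ccccc1` has not yet been measured. It differs from compound 3 by hydrogen in place of methoxy on an aromatic carbon. Within the data shown here, this is the same kind of change as the one between compound 2 and compound 1, but not the same: in the earlier pair the methoxy left an aromatic carbon para to a large group, whereas here it leaves an aromatic carbon of a six-membered aromatic ring of carbon only, part of a fused or bridged system of two rings, meta to a fused ring and para to a fused ring. Among the measured compounds shown here, the measured step is the only guide, and it was made on a different ring, so the expectation for compound 4 is held loosely. Compound 4 is expected to give 15000 nM in this assay, with a likely range from 5000 nM to 50000 nM. The step expected from compound 3 to compound 4 is a 2.0-fold higher number from compound 3 to compound 4 (0.31 log units; beyond the scatter), a smaller loss than a 7.2-fold higher number from compound 2 to compound 1 (0.86 log units; beyond the scatter), as nothing measured shows how much a methoxy at this other place contributes.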

Compound 4, concentration for 50% growth inhibition: 1400 nM
Beside the measured number, compound 4's estimate is 11-fold (1.03 log units) above it, outside the stated range (below it).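

In this assay, hydrogen in place of methoxy on the six-membered aromatic ring of carbon only, part of the fused system, gave a stronger inhibitor of growth, with a 5.3-fold lower number from compound 3 to compound 4 (0.72 log units; beyond the scatter). Set beside the earlier pair, the same kind of change moved the number in opposite directions, so in this series its effect on one core gives no safe guide to its effect on another: the same change on two cores in this assay, a 7.2-fold higher number (0.86 log units; beyond the scatter) from compound 2 to compound 1 and a 5.3-fold lower number (0.72 log units; beyond the scatter) from compound 3 to compound 4, 38-fold (1.58 log units) apart, beyond the scatter of two such steps What this does not show is why the two steps part, since the pairs differ in two ways at once: the methoxy leaves a different place in each, and the rest of the molecule is also different, and two pairs cannot separate these, nor do they show that either direction holds beyond the four compounds.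

Open, on these data alone, is what the change does when the methoxy leaves the same place on both cores, which would show whether the place or the rest of the molecule sets the direction. Also open, as far as these compounds go, is whether a hydroxy group, an ethoxy group or a chlorine atom at the place named for compound 3 would follow the hydrogen of compound 4 or the methoxy of compound 3.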